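Swapping a ring substituent on a two-point-diverged pair

The source may report more compounds than this note shows. Statements on the series, on what has been measured and on what is new or still open speak of the compounds shown alone.

Compound 1 `Nc1ccccc1NC(=O)/C=C/c1ccc(Cn2cnc3c(Nc4cccc(Cl)c4)nc(Cl)nc32)cc1` and compound 2 `Nc1ccccc1NC(=O)c1ccc(Cn2cnc3c(Nc4cccc(OC(F)(F)F)c4)nc(Cl)nc32)cc1` differ in more than one place, so only their two values are compared. In a functional assay on HepG2 cells (Homo sapiens) for antiproliferative activity, read by CCK-8 assay, with a stated time of 72 h, tested at 8 uM (a lower number here means a weaker effect, a higher number a stronger effect of the compound at the concentration tested), compound 1 gives 49.3%, while compound 2 gives 31.2%, the lower of the two numbers. Compound 3 `Nc1ccccc1NC(=O)c1ccc(Cn2cnc3c(Nc4cccc(Cl)c4)nc(Cl)nc32)cc1` carries the change chloro in place of trifluoromethoxy on an aromatic carbon relative to compound 2. Among the compounds with values here, with no single-point step known, the step of a number 6.8 percentage points higher from compound 2 to compound 3 (within the scatter) is expected to be small and upward, close to the scatter. Compound 3 is accordingly estimated at 38%, within a range of 22% to 55%.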

Compound 3, a percentage reported as inhibition, at one concentration (the size of the read-out at that concentration, not a potency): 66.7%
The estimate for compound 3 lay 28.7 percentage points below the measured number, and the stated range ends below it.
By their numbers in this assay, from the lowest: compound 2; then compound 1; then compound 3.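

In this assay, within the data shown here, chloro in place of trifluoromethoxy on the aromatic carbon gives a number 35.5 percentage points higher from compound 2 to compound 3 (beyond the scatter) and provides the first single-change reading at this position, where the two groups are clearly not interchangeable. With the 3-chlorophenyl group held constant, (2-aminophenyl)carbamoyl in place of 2-((2-aminophenyl)carbamoyl)ethenyl gives a number 17.4 percentage points higher from compound 1 to compound 3 (beyond the scatter) and shows that the other end of the molecule also affects the read-out. Nothing available explains either step.

As far as these compounds go, whether chloro is specifically favoured here remains open, since fluoro, methyl, methoxy or a nitrile at this place could read differently. It is also unknown whether the same step would hold with the 2-((2-aminophenyl)carbamoyl)ethenyl chain in place.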